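Thiocyanate in Place of Hydroxylamine on the Side Chain

The source may report more compounds than this note shows. Statements on the series, on what has been measured and on what is new or still open speak of the compounds shown alone.

Compound 3 `ONCCCc1c[nH]c2ccc(F)cc12` gives 21 nM in an assay on isolated protein for inhibition of Myeloperoxidase (Homo sapiens), read by ELISA, with a stated time of 5 min (a lower number here means a stronger inhibitor, a higher number a weaker inhibitor), the higher of the two numbers recorded, with compound 1 `NCCSCCc1c[nH]c2ccc(F)cc12` nearest at 8 nM. Compound 2 `CCCc1c[nH]c2ccc(F)cc12` returns only > 100 nM, which is a limit of the assay (the limit of > 100 nM in this assay, at which 1 of the 3 values shown sits). Compound 4 `N#CSCCCc1c[nH]c2ccc(F)cc12` carries cyanosulfanyl in place of hydroxyamino on a saturated chain carbon, three bonds along the chain from an aromatic carbon. For the measured compounds named here, the steps that bear on this are an at least 4.7-fold lower number from compound 2 to compound 3 (0.67 log units; beyond the scatter) and an at least 12-fold higher number from compound 1 to compound 2 (1.09 log units; beyond the scatter), both showing a lower number when the chain ends in a hydroxyamino or (2-aminoethyl)sulfanyl group rather than in hydrogen or methyl, while a 2.6-fold higher number from compound 1 to compound 3 (0.42 log units; beyond the scatter) is modest. In compound 4 the hydroxyamino group with its hydrogen-bond donors leaves, so in this assay a rise is expected, a 2.9-fold higher number from compound 3 to compound 4 (0.46 log units; beyond the scatter). Compound 4 is estimated at 60 nM, with a range from 20 nM to 200 nM.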

Compound 4, half-maximal inhibitory concentration: 23 nM
The estimate for compound 4 lay 2.6-fold (0.42 log units) above the measured number, within the range that was stated.
By their numbers in this assay, from the lowest: compound 1; then compounds 3 and 4 (each within the scatter of the next). At a limit, above all of these: compound 2.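

In this assay, hydrogen-bond donors on the chain end are not required at this position: cyanosulfanyl, which has none, gives a 1.1-fold higher number from compound 3 to compound 4 (0.04 log units; within the scatter). It also gives an at least 4.3-fold lower number from compound 2 to compound 4 (0.63 log units; beyond the scatter), so a second, unrelated end group shares the gain of compound 3, while a 2.9-fold higher number from compound 1 to compound 4 (0.46 log units; beyond the scatter) leaves the (2-aminoethyl)sulfanyl chain of compound 1 ahead. The reading for compound 2 is a limit, not a number: the limit of > 100 nM in this assay, at which 1 of the 4 values shown sits.

On these data alone, whether a simple amine, a carboxylic acid or a longer chain at this carbon would reach compound 1 remains open.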